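A few compounds are considered here, and "the series" means these few. Any claim that something is new, unique, unknown or untested is made for them only; others in the source may bear on it.

Of the compounds shown here, two from this series have been measured in a functional assay on A549 cells (Homo sapiens) for antiproliferative activity, read by MTT assay; a higher number here means a weaker inhibitor, a lower number a stronger inhibitor. Compound 1 `O=C(Nc1cccc(CNc2ncnc3ccccc23)c1)Nc1cccc(C(F)(F)F)c1` carries a trifluoromethyl on the phenyl of the urea and an unsubstituted shared core, and in this assay compound 1 gives 44200 nM. Compound 2 `COc1ccc(NC(=O)Nc2cccc(CNc3ncnc4cc(OC)c(OC)cc34)c2)cc1` has a methoxy on the phenyl of the urea and two methoxy groups on the shared core, and in this assay compound 2 gives 24500 nM. Compound 2 thus shows the lower of the two numbers, but its gap to compound 1 lies within the scatter of this kind of measurement.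

Compound 3 `COc1cc2ncnc(NCc3cccc(NC(=O)Nc4ccc([N+](=O)[O-])cc4)c3)c2cc1OC` has not yet been measured in this assay. It differs from compound 2 only at the urea phenyl: nitro in place of methoxy on an aromatic carbon. Going by the values given here, no measured pair in this set shows such a change, so the expectation rests on compound 2 alone, with a step of a 1.2-fold lower number from compound 2 to compound 3 (0.09 log units; within the scatter) expected to stay within the scatter. Compound 3 is estimated at 20000 nM, within a range from 7000 nM to 60000 nM.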

Compound 3, half-maximal inhibitory concentration: > 50000 nM
Compound 3 ended at the assay's limit; the forecaster's own chance of this, stated with the estimate: 10%; middle value at least 2.5-fold (0.39 log units) from the limit.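

This position on the urea phenyl now has its first readable step, with nitro in place of methoxy giving an at least 2.0-fold higher number from compound 2 to compound 3 (0.30 log units; that floor lies within the scatter). In this assay compound 3 gives > 50000 nM, which is a limit of the assay and not a number. The change therefore brought no gain here, yet the floor of the step stays within the scatter and the true size of the step cannot be read, and this is the only such value so far: the limit of > 50000 nM in this assay, at which 1 of the 3 values shown sits.

Compound 1 and compound 2 differ in more than one place, so the part played by the two methoxy groups on the shared core cannot be separated from that of the group on the urea phenyl. On these data alone, how an amine or a carboxylic acid at this same place on the urea phenyl would read also remains open.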